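Notes on the step from compound 3 to compound 4

The source may hold more compounds than are shown below. What is called first, only, known or untested is meant among the compounds shown, and "the series" means these compounds.

Values in a functional assay on a cell-free system (Platelet, plasma, Homo sapiens) for inhibition; a lower number here means a stronger inhibitor, a higher number a weaker inhibitor:
- compound 1 `O=C(Nc1ccc(OCc2ccc(F)cc2)cc1)C1CCCNC1`: 116000 nM
- compound 2 `N=C(N)N1CCCC(C(=O)Nc2cccc(OCc3ccc(F)cc3)c2)C1`: 274000 nM
- compound 3 `O=C(Nc1cccc(OCc2ccc(F)cc2)c1)C1CCNCC1`: 68000 nM

Compound 3 at 68000 nM and compound 1 at 116000 nM lie within the scatter of each other, so neither ranks ahead of the other. Compound 2 stands apart from this pair.

The next compound, compound 4 `O=C(Nc1cccc(OCc2ccc(-c3ccccc3F)cc2)c1)C1CCNCC1`, carries 2-fluorophenyl in place of fluoro on an aromatic carbon, para to a large group: 2-fluorophenyl in place of fluoro on an aromatic carbon. Among the measured compounds shown here, only one measured step is available, a 4.0-fold lower number from compound 2 to compound 3 (0.61 log units; beyond the scatter). It replaces the group on the carbonyl carbon, so it bears only indirectly on a change at this aromatic carbon. For the measured compounds named here, no measured compound varies the fluoro position, and the size of that one step is the sole guide to how far a single change can move this assay. A step of similar size is the working expectation, towards a lower number, held loosely given the absence of direct evidence. The estimated step is a 3.4-fold lower number from compound 3 to compound 4 (0.53 log units; beyond the scatter). The expected value for compound 4 is 20000 nM, with an estimated range of 3000 nM to 100000 nM.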

Compound 4, half-maximal inhibitory concentration: 62700 nM
Estimate against measurement, compound 4: 3.1-fold (0.50 log units) below, within the range that was stated.
By their numbers in this assay, from the lowest: compounds 4, 3 and 1 (each within the scatter of the next); then compound 2.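

In this assay, 2-fluorophenyl in place of fluoro on this aromatic carbon gives a 1.1-fold lower number from compound 3 to compound 4 (0.04 log units; within the scatter), so compound 3 and compound 4 cannot be told apart, even though the entering group brings a six-membered aromatic ring. Among the compounds shown here, the only earlier step, a 4.0-fold lower number from compound 2 to compound 3 (0.61 log units; beyond the scatter), came from a change on the carbonyl carbon; this pair gives the first reading at the aromatic carbon, and there an added ring leaves the number within the scatter. No evidence on hand accounts for this result.

One pair cannot show whether this aromatic carbon tolerates groups of other kinds, and a carboxylic acid or an amine here could give a reading quite unlike that of compound 4 at 62700 nM. As far as these compounds go, it is also open whether the fluorine on the added ring contributes anything, which plain phenyl at the same place would test, and whether any change at this carbon can bring the series clearly below compound 3 at 68000 nM.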